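This account rests on a few compounds, and the source may have more. Where it says the series, first, only, none or still open, it means among the compounds named here.

Series on the shared core of compound 1 `CC(C)(C)c1ccccc1Oc1ncccc1NC(=O)Nc1ccccc1`, compound 2 `CC(C)(C)c1ccccc1Oc1ncccc1Nc1nnc(-c2ccccc2)s1` and compound 3 `CC(C)(C)c1ccccc1Oc1ncccc1Nc1nnc(-c2ccncc2)s1`. In an assay on HEK293 cells for displacement of a labelled ligand from P2Y purinoceptor 1 (Homo sapiens), read by scintillation counting, with a stated time of 1 h (on this read-out lower numbers stand for stronger inhibition and higher numbers for weaker inhibition), compound 1 gives 41 nM, compound 2 gives 11 nM and compound 3 gives 275 nM, the highest of the three numbers, with compound 1 nearest to it and compound 2 furthest. Among the compounds with values here, the only step between measured compounds that differ in one place is a 25-fold higher number from compound 2 to compound 3 (1.40 log units; beyond the scatter). Compound 4 `CC(C)(C)c1ccccc1Oc1ncccc1Nc1nnc(C(=O)O)s1` differs from compound 3 by carboxy in place of pyridin-4-yl on an aromatic carbon. Within the data shown here, that position has been varied once in this assay, and the step was large and upward, while no measured compound carries a carboxy group, so the expectation rests on that single step. An upward step a 5.5-fold higher number from compound 3 to compound 4 (0.74 log units; beyond the scatter) in this assay is therefore expected. Compound 4 is estimated at 1500 nM, with an expected range from 300 nM to 8000 nM.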

Compound 4, inhibition constant: 2900 nM
Compound 4: the middle estimate sits 1.9-fold (0.29 log units) below what was measured; measured number inside the range.
By their numbers in this assay, from the lowest: compound 2; then compound 1; then compound 3; then compound 4.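

In this assay, carboxy on this aromatic carbon gives an 11-fold higher number from compound 3 to compound 4 (1.02 log units; beyond the scatter); measured against phenyl it gives a 260-fold higher number from compound 2 to compound 4 (2.42 log units; beyond the scatter), so both replacements of phenyl shown here raise the number, carboxy more than pyridin-4-yl. Replacing phenylcarbamoyl on the nitrogen with 5-carboxy-1,3,4-thiadiazol-2-yl gives a 71-fold higher number from compound 1 to compound 4 (1.85 log units; beyond the scatter). Nothing available accounts for these rises.

Open, as far as these compounds go, is whether the carboxy group itself sets the size of the step. A methyl ester or a primary amide on the same carbon would test that, as would a phenyl ring bearing a carboxylic acid.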